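The source may report more compounds than this note shows. Statements on the series, on what has been measured and on what is new or still open speak of the compounds shown alone.

Measured in a functional assay, with stated times of 30 s and 6 min, in the presence of a further agent that is not named here; a lower number here means a stronger inhibitor, a higher number a weaker inhibitor:

- compound 1 `CCCCOc1cc(OC)c(Br)cc1C(C)=O`: 38200000 nM
- compound 2 `CCOc1cc(OC)ccc1C(C)=O`: 6600000 nM

Compound 2 has the lower of the two numbers, which makes it the stronger inhibitor of this pair, and the gap to compound 1 lies beyond the scatter. Both values are high, and two compounds define no trend.

The next compound to consider is compound 3 `CCCCOc1cc(OC)ccc1C(C)=O`, which is related to compound 2 by one change: ethyl in place of hydrogen on a saturated chain carbon, two bonds along the chain from an oxygen on an aromatic ring. Put shortly, ethoxy becomes butoxy.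

For the measured compounds named here, no pair of measured compounds differs in one place only, so this change has no direct measured precedent. Going by the values given here, the only butoxy compound with a value is compound 1 at 38200000 nM, and that gives weak support for a move towards a higher number. A modest step in that direction is expected, slightly beyond the scatter, though a result within the scatter would not be surprising. The expected change is a 1.5-fold higher number from compound 2 to compound 3 (0.18 log units; within the scatter). The estimated value for compound 3 is 10000000 nM, with an expected range of 3000000 nM to 30000000 nM.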

Compound 3, half-maximal inhibitory concentration: 15600000 nM
For compound 3 the middle estimate is 1.6-fold (0.19 log units) below the measured one, within the range that was stated.
By their numbers in this assay, from the lowest: compound 2; then compound 3; then compound 1.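

Read in this assay the change from ethoxy to butoxy gives a 2.4-fold higher number from compound 2 to compound 3 (0.37 log units; beyond the scatter) and so provides the first direct reading at this chain position: on the shared core, the longer chain weakens inhibition modestly rather than leaving it unchanged. For the compounds shown here, compound 3 also isolates the bromo group for the first time, since hydrogen in place of bromo on an aromatic carbon gives a 2.4-fold lower number from compound 1 to compound 3 (0.39 log units; beyond the scatter) and the butoxy compound without bromo is therefore the stronger inhibitor of that pair. Both single changes can now be read separately, each modest and beyond the scatter, but no measurement available here bears on the reason for either step.

From the compounds shown here alone, two chain lengths define no trend, so it remains open whether a longer chain such as hexyloxy would continue the weakening, or whether a chain ending in an amine or a carboxylic acid would reverse it. Going by these compounds, the bromo step has been read only with butoxy present, so it is also open whether bromo or chloro on the ethoxy compound would behave in the same way.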